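Methyl to Ethyl on Compound 2: What to Expect

The source may hold more compounds than are shown below. What is called first, only, known or untested is meant among the compounds shown, and "the series" means these compounds.

Measured so far:
compound 1 `Cc1nc(Nc2ccc(Cl)cc2)c2cc[nH]c2n1` with 224000000 nM
compound 2 `Cc1ccc(Nc2[nH]c(C)nc3nccc2-3)cc1` with 759000000 nM

In a functional assay on the whole organism for inhibition, with Nicotiana tabacum as the target (on this read-out lower numbers stand for stronger inhibition and higher numbers for weaker inhibition), compound 1 gives 224000000 nM, and compound 2 gives 759000000 nM. Of the two numbers, compound 2 stands highest, and its gap to compound 1 lies beyond the usual scatter, so compound 2 is the weaker inhibitor of the pair. Among the measured compounds shown here, the two compounds differ in several places at once, so no single-point step between them can be read off.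

Compound 3 `CCc1ccc(Nc2[nH]c(C)nc3nccc2-3)cc1` is built from compound 2 by one change: methyl in place of hydrogen on a saturated chain carbon bound to an aromatic carbon. For the measured compounds named here, no measured pair in this set shows this change, so there is no step to lean on. The expectation is therefore a step of no clear direction, likely within the scatter, and the estimated step is a 1.1-fold lower number from compound 2 to compound 3 (0.04 log units; within the scatter). For compound 3 the estimated value in this assay is 700000000 nM, with a range from 250000000 nM to 2000000000 nM.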

Compound 3, half-maximal inhibitory concentration: 214000000 nM
For compound 3 the middle estimate is 3.3-fold (0.51 log units) above the measured one; measured number outside the range, below it.
By their numbers in this assay, from the lowest: compounds 3 and 1 (each within the scatter of the next); then compound 2.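

In this assay, among the compounds shown here, the change of methyl to ethyl gives a 3.5-fold lower number from compound 2 to compound 3 (0.55 log units; beyond the scatter) and so offers the first single-place reading in this set. Methyl in place of hydrogen on a saturated chain carbon bound to an aromatic carbon is therefore not a silent change here: it moves the number toward stronger inhibition, by a step beyond the scatter, which the earlier pair, differing in several places at once, could not show. Nothing measured on these compounds accounts for this step.

As far as these compounds go, one step on one pair fixes no trend along the chain, so it remains open whether a longer chain such as propyl would extend the step, hold it or reverse it. Also open, from the compounds shown here alone, is how a polar group such as an amine or a carboxylic acid would read at this same place.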